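This account rests on a few compounds, and the source may have more. Where it says the series, first, only, none or still open, it means among the compounds named here.

In a functional assay on HCT-15 cells (Homo sapiens) for cytotoxicity, read by ELISA, with a stated time of 2 days (on this read-out higher numbers stand for weaker inhibition and lower numbers for stronger inhibition), compound 1 (`Oc1cccc(-c2cc(-c3ccccc3)cc(-c3ccsc3)n2)c1`) gives 7660 nM and compound 2 (`Oc1cccc(-c2cc(-c3ccccc3)cc(-c3ccco3)n2)c1`) gives 13500 nM on the shared core. These two values lie within the scatter of each other, so compound 2 cannot be separated from compound 1 on these numbers. Compound 3 (`Oc1cccc(-c2cc(-c3ccccc3)cc(-c3cccc(O)c3)n2)c1`) carries 3-hydroxyphenyl in place of furan-2-yl on an aromatic carbon next to the ring nitrogen (3-hydroxyphenyl in place of furan-2-yl on an aromatic carbon). Among the compounds with values here, the only measured step that bears on this change is a 1.8-fold higher number from compound 1 to compound 2 (0.25 log units; within the scatter) and it exchanges thiophen-3-yl for furan-2-yl, so it says little directly about a six-membered aromatic ring of carbon only entering at that place. No step beyond the scatter is therefore expected in this assay and the estimated step is a 1.4-fold lower number from compound 2 to compound 3 (0.13 log units; within the scatter) with wide uncertainty. For compound 3 the estimated value is 10000 nM with an expected range from 3000 nM to 30000 nM on this read-out.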

Compound 3, half-maximal inhibitory concentration: 18400 nM
Estimate against measurement, compound 3: 1.8-fold (0.26 log units) below; measured number inside the range.
By their numbers in this assay, from the lowest: compounds 1, 2 and 3 (each within the scatter of the next, the first and the last beyond it).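

At this place on the shared core, on an aromatic carbon next to the ring nitrogen, a six-membered aromatic ring of carbon only can now be compared with the two five-membered rings. In this assay, within the data shown here, 3-hydroxyphenyl in place of furan-2-yl gives a 1.4-fold higher number from compound 2 to compound 3 (0.13 log units; within the scatter), whereas the same group in place of thiophen-3-yl gives a 2.4-fold higher number from compound 1 to compound 3 (0.38 log units; beyond the scatter), the first modest step beyond the scatter at this place. No measurement shown here accounts for that step.

The compounds shown leave open what plain phenyl would give at this place, and so whether the hydroxyl of 3-hydroxyphenyl counts for anything in this step. They also leave open how an amine, a carboxylic acid or a longer alkyl chain would read there.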